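Moving the methoxy group on a weak inhibitor series

The compounds below may be only part of what the source reports. "The series", "measured", "known", "first", "only" and "open" are said of these compounds alone.

Within the data shown here, the three compounds measured so far share one core, a pyranyl-bearing heteroaromatic system linked through a nitrogen to a benzylic carbon, and differ only in the aryl group on that carbon. Compound 1 `Oc1cccc(CNc2ncnc3c2ncn3C2CCCCO2)c1` gives 81000 nM in an ADME assay on K562 cells (Homo sapiens) for cytotoxicity, with a stated time of 72 h; a lower number here means a stronger inhibitor, a higher number a weaker inhibitor. Compound 3 `COc1ccccc1CNc1ncnc2c1ncn2C1CCCCO1` gives 97000 nM in this assay, and it holds the highest of the two numbers, though its nearest neighbour is compound 1, with a 1.2-fold higher number from compound 1 to compound 3 (0.08 log units; within the scatter). Compound 2 `Oc1ccc(CNc2ncnc3c2ncn3C2CCCCO2)cc1` is reported only as a limit in this assay, > 100000 nM, and not as a number (the limit of > 100000 nM in this assay, at which 1 of the 3 values shown sits). The step of an at least 1.0-fold lower number from compound 2 to compound 3 (0.01 log units; that floor lies within the scatter) likewise rests on that limit.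

Compound 4 `COc1ccc(CNc2ncnc3c2ncn3C2CCCCO2)cc1` has not yet been measured. It differs from compound 3 by 4-methoxyphenyl in place of 2-methoxyphenyl on a saturated chain carbon bound to a nitrogen on an aromatic ring. The nearest measured comparison is the shift of the hydroxy group, an at least 1.2-fold higher number from compound 1 to compound 2 (0.09 log units; that floor lies within the scatter), which at its floor is within the scatter. Among the measured compounds shown here, no measured step moves a methoxy group, so the evidence is thin. The expectation is therefore a step of a 1.1-fold higher number from compound 3 to compound 4 (0.05 log units; within the scatter), essentially none beyond the scatter, with a real chance that the assay reports only a limit. Compound 4 is estimated at 110000 nM, within a range of 50000 nM to 250000 nM.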

Compound 4, half-maximal inhibitory concentration: > 100000 nM
Compound 4 ended at the assay's limit; the forecaster's own chance of this, stated with the estimate: 55%; the middle value lies beyond the limit too.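

Compound 4 gives the first measured shift of a methoxy group at this position, on a saturated chain carbon bound to a nitrogen on an aromatic ring, and in this assay 4-methoxyphenyl in place of 2-methoxyphenyl gives an at least 1.0-fold higher number from compound 3 to compound 4 (0.01 log units; that floor lies within the scatter), so this shift shows no change that can be told from the scatter. The comparison with the 3-hydroxyphenyl compound reads the same way, with an at least 1.2-fold higher number from compound 1 to compound 4 (0.09 log units; that floor lies within the scatter), and this floor also leaves no measured difference beyond the scatter. The step from compound 2 to compound 4, methyl in place of hydrogen on an oxygen on an aromatic ring, cannot be read, because both compounds are reported only as a limit of the assay: the limit of > 100000 nM in this assay, at which 2 of the 4 values shown sit.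

The compounds shown leave open how far compound 2 and compound 4 actually lie beyond that limit, and whether any aryl group on this carbon can give a number beyond the scatter of the others. They also leave open what an amine or a carboxylic acid on the phenyl ring, or a longer chain in place of the single carbon, would do in this assay.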